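Hydroxamate linker length in the shared core series

This account rests on a few compounds, and the source may have more. Where it says the series, first, only, none or still open, it means among the compounds named here.

Compound 1 `Nc1nc2cc(-c3nn(CCCCCCCCCC(=O)NO)c4ncnc(N)c34)ccc2o1` gives 28600 nM in a functional assay on HepG2 cells (Homo sapiens) for inhibition, read by MTT assay, with a stated time of 72 h; a lower number here means a stronger inhibitor, a higher number a weaker inhibitor. Compound 2 `Nc1nc2cc(-c3nn(CC(=O)NO)c4ncnc(N)c34)ccc2o1` returns only a limit in this assay, reported as > 150000 nM, so no number stands for compound 2; it sits at the limit of > 150000 nM in this assay, at which 1 of the 2 values shown sits. Compound 3 `Nc1nc2cc(-c3nn(CCC(=O)NO)c4ncnc(N)c34)ccc2o1` has not been measured; it differs from compound 2 by (hydroxycarbamoyl)methyl in place of hydroxycarbamoyl on a saturated chain carbon bound to an aromatic nitrogen. Among the compounds with values here, no step between measured compounds is at hand, so any expectation here is loose; a small gain, at most within the scatter, is expected as an at least 1.2-fold lower number from compound 2 to compound 3 (0.09 log units; that floor lies within the scatter). Compound 3 is expected at 120000 nM, with a range from 50000 nM to 250000 nM.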

Compound 3, half-maximal inhibitory concentration: > 150000 nM
Compound 3 gave a limit, no number (the forecaster's own chance of this, stated with the estimate: 60%); middle value at least 1.2-fold (0.09 log units) away from the limit.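

Lengthening the chain by one unit does not bring the series off the limit in this assay: compound 2 and compound 3 both return only limits, so the step between them cannot be read: the limit of > 150000 nM in this assay, at which 2 of the 3 values shown sit.

Against the long chain, the short 2-(hydroxycarbamoyl)ethyl chain gives an at least 5.2-fold higher number from compound 1 to compound 3 (0.71 log units; beyond the scatter), so among these compounds only the longest chain returns a number.

Open, as far as these compounds go, is whether a 4-(hydroxycarbamoyl)butyl chain returns a number in this assay, and whether a carboxylic acid in place of the hydroxycarbamoyl end of the long chain keeps the reading of compound 1.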